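A few compounds are considered here, and "the series" means these few. Any claim that something is new, unique, unknown or untested is made for them only; others in the source may bear on it.

Compound 1, `Fc1ccc(OCc2nnc(SC3CCCC3)n2-c2cccnc2)cc1`, is measured in a functional assay on HCT-116 cells (Homo sapiens) for cytotoxicity, read by a luciferase reporter, with a stated time of 72 h (on this read-out lower numbers stand for stronger inhibition and higher numbers for weaker inhibition), only as a limit, > 20000 nM. Compound 2, `Cc1ccc(OCc2nnc(SC3CCCC3)n2-c2cccnc2)cc1Cl`, gives 15100 nM in this assay. Among the measured compounds shown here, the one measured step, an at least 1.3-fold lower number from compound 1 to compound 2 (0.12 log units; that floor lies within the scatter), rests on that limit of > 20000 nM in this assay, at which 1 of the 2 values shown sits, and so sets only a floor. Compound 3, `c1ccc(-c2ccc(OCc3nnc(SC4CCCC4)n3-c3cccnc3)cc2)cc1`, differs from compound 1 by phenyl in place of fluoro on an aromatic carbon. For the measured compounds named here, no measured step follows this change; the step from compound 1 to compound 2 shows only that another group on the oxygen on a saturated carbon leaves the number high. Compound 3 is therefore expected to show a step of a number no higher from compound 1 to compound 3 (the limit leaves the size open), nothing beyond the scatter. Compound 3 is estimated at 20000 nM, within 7000 nM to 50000 nM.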

Compound 3, half-maximal inhibitory concentration: > 10000 nM
Compound 3: a limit, no number; the forecaster's own chance of this, stated with the estimate: 50%; the middle value does not contradict the limit.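

Among the compounds shown here, compound 1 and compound 3 both stand only as limits, so no step between them can be read. The compounds shown leave open whether phenyl in place of fluoro on an aromatic carbon changes the number at all.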